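This account rests on a few compounds, and the source may have more. Where it says the series, first, only, none or still open, it means among the compounds named here.

Working notes on the series in a functional assay on HCT-116 cells (Homo sapiens) for antiproliferative activity, read by MTT assay, with a stated time of 72 h; a higher number here means a weaker inhibitor, a lower number a stronger inhibitor. Compound 1 `NC1=NC2(CCOCC2)N(OCCCOc2ccccc2)C(N)=N1` gives 6010 nM, compound 2 `NC1=NC2(CCOCC2)N(OCCCOc2cccc(Cl)c2Cl)C(N)=N1` gives 5 nM, and compound 3 `NC1=NC2(CCOCC2)N(OCCCOc2ccc(Cl)c(Cl)c2)C(N)=N1` gives 90 nM, which puts compound 3 in the middle of the three numbers. Compound 4 `NC1=NC2(CCOCC2)N(OCCCOc2cc(Cl)c(Cl)cc2Cl)C(N)=N1` follows from compound 3 by one change: chloro in place of hydrogen on an aromatic carbon. This is chloro in place of hydrogen on an aromatic carbon, turning 3,4-dichlorophenyl into 2,4,5-trichlorophenyl.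

Going by the values given here, three measured steps bear on it. Both dichlorophenyl compounds lie well under compound 1: a 67-fold lower number from compound 1 to compound 3 (1.82 log units; beyond the scatter) and a 1200-fold lower number from compound 1 to compound 2 (3.08 log units; beyond the scatter). Chloro placement also counts, as an 18-fold higher number from compound 2 to compound 3 (1.26 log units; beyond the scatter) shows, and compound 2 likewise carries a chloro group ortho to a large group. Among the compounds with values here, no measured compound holds the 2,4,5-trichlorophenyl group, so the transfer is uncertain. A moderately large drop in this assay is expected, beyond the scatter, with the estimated step being a 6.0-fold lower number from compound 3 to compound 4 (0.78 log units; beyond the scatter). The estimated value for compound 4 is 15 nM, with an expected range of 3 nM to 70 nM.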

Compound 4, half-maximal inhibitory concentration: 2750 nM
The estimate for compound 4 lay 180-fold (2.26 log units) below the measured number, and the stated range ends below it.
By their numbers in this assay, from the lowest: compound 2; then compound 3; then compound 4; then compound 1.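

In this assay, a third chloro group on the aromatic ring does not extend the gain seen with the dichlorophenyl compounds, and this position, ortho to a large group, reverses much of it (a 31-fold higher number from compound 3 to compound 4 (1.49 log units; beyond the scatter)). A chloro group ortho to a large group is therefore not enough for a low number, since compound 4 also carries one and still shows a large loss against the 2,3-dichlorophenyl compound (a 550-fold higher number from compound 2 to compound 4 (2.74 log units; beyond the scatter)), while only a modest margin remains over the unsubstituted phenyl compound (a 2.2-fold lower number from compound 1 to compound 4 (0.34 log units; beyond the scatter)). Nothing measured on these compounds accounts for the rise.

On these data alone, whether the loss follows from this chloro group alone or from the full 2,4,5-trichlorophenyl pattern stays open. Also open, as far as these compounds go, is how a fluoro or methyl group at the same aromatic carbon would read in this assay.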